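Replacing a second aryl ester with a nitro group

A few compounds are considered here, and "the series" means these few. Any claim that something is new, unique, unknown or untested is made for them only; others in the source may bear on it.

Compounds measured in an ADME assay on a cell-free system (plasma, Homo sapiens) for metabolic stability, with Plasma (Rattus norvegicus) as the target, read by HPLC, at pH 7.4; a lower number here means that the compound disappears faster, a higher number that the compound lasts longer:
compound 1 `CC(=O)Oc1ccccc1C(=O)O[C@H]1CO[C@H]2[C@@H]1OC[C@H]2OC(=O)c1ccccc1O`: 0.019 h
compound 2 `CC(=O)Oc1ccccc1C(=O)O[C@H]1CO[C@H]2[C@@H]1OC[C@H]2OC(=O)c1ccnn1C`: 0.0642 h
compound 3 `COc1ccccc1C(=O)O[C@@H]1CO[C@H]2[C@@H]1OC[C@@H]2OC(=O)c1ccccc1OC(C)=O`: 0.0165 h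

Compound 3 gives the lowest number of the three in this assay. Its nearest neighbour is compound 1, shown by a 1.2-fold lower number from compound 1 to compound 3 (0.06 log units; within the scatter); its furthest is compound 2, shown by a 3.9-fold lower number from compound 2 to compound 3 (0.59 log units; beyond the scatter).

Compound 4 is `CC(=O)Oc1ccccc1C(=O)O[C@H]1CO[C@H]2[C@@H]1OC[C@H]2O[N+](=O)[O-]`. It differs from compound 3 in one place: nitro in place of (2-methoxyphenyl)carbonyl on an oxygen on a saturated carbon.

Going by the values given here, two steps bear on this change. Each of them alters the same side of the shared core. The step of a 3.4-fold higher number from compound 1 to compound 2 (0.53 log units; beyond the scatter) shows that swapping one group there for another of a different kind can move the number beyond the scatter, whereas a 1.2-fold lower number from compound 1 to compound 3 (0.06 log units; within the scatter) shows that a small change within the same kind of group does not. Among the compounds with values here, the change to compound 4 is of the larger kind, so a step beyond the scatter in this assay seems plausible, most likely upward, since the only beyond-scatter step here went up when the phenyl carbonyl was exchanged.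

Compound 4 is therefore expected to give 0.04 h, within 0.015 h to 0.12 h, an estimated step of a 2.4-fold higher number from compound 3 to compound 4 (0.38 log units; beyond the scatter).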

Compound 4, half-life: 0.00314 h
Compound 4: the middle estimate sits 13-fold (1.11 log units) above what was measured; measured number below the stated range.
By their numbers in this assay, from the lowest: compound 4; then compounds 3 and 1 (each within the scatter of the next); then compound 2.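

In this assay, going by these compounds alone, the earlier compounds showed that the group on this oxygen on a saturated carbon can move the number, but all of those groups were aromatic carbonyls. Nitro, which has no ring, gives the lowest number of the set, with a 5.3-fold lower number from compound 3 to compound 4 (0.72 log units; beyond the scatter), a 6.1-fold lower number from compound 1 to compound 4 (0.78 log units; beyond the scatter) and a 20-fold lower number from compound 2 to compound 4 (1.31 log units; beyond the scatter). Compound 4 therefore stands beyond the scatter from every other compound shown, so (2-methoxyphenyl)carbonyl, (2-hydroxyphenyl)carbonyl and (1-methyl-1H-pyrazol-5-yl)carbonyl at this place all go with a longer half-life than nitro, and the widest gap is to the last of these.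

Nothing shown gives a measured reason for this drop. A free hydroxyl or a plain alkyl ether on the same oxygen would help to tell whether the low number goes with nitro itself or with the loss of the aromatic carbonyl group.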